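Ethyl on the amide nitrogen of a chlorophenyl diamide

The compounds below may be only part of what the source reports. "The series", "measured", "known", "first", "only" and "open" are said of these compounds alone.

Measured so far:
compound 1 `CCN(CC)CCNC(=O)CC(CC(=O)NC1Cc2ccccc2C1)c1ccc(Cl)cc1` — 48600 nM
compound 2 `O=C(CC(CC(=O)NC1Cc2ccccc2C1)c1ccc(Cl)cc1)NCCN1CCCC1` — 50900 nM

Among the measured compounds shown here, in a functional assay on A549 cells (Homo sapiens) for inhibition (on this read-out lower numbers stand for stronger inhibition and higher numbers for weaker inhibition), compound 1 stands together with compound 2, the only other number, at a 1.0-fold higher number from compound 1 to compound 2 (0.02 log units; within the scatter), so the two are indistinguishable here. Compound 3 `CCN(CC)CCNC(=O)CC(CC(=O)N(CC)C1Cc2ccccc2C1)c1ccc(Cl)cc1` differs from compound 1 by ethyl in place of hydrogen on an amide-type nitrogen. For the measured compounds named here, no measured step touches the amide-type nitrogen; the one step known, a 1.0-fold higher number from compound 1 to compound 2 (0.02 log units; within the scatter), concerns the saturated chain carbon and gives no guide. With nothing to point either way, no step beyond the scatter is expected, a 1.0-fold higher number from compound 1 to compound 3 (0.01 log units; within the scatter). Compound 3 is therefore estimated at 50000 nM, in the range 15000 nM to 160000 nM.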

Compound 3, half-maximal inhibitory concentration: 18400 nM
Estimate against measurement, compound 3: 2.7-fold (0.43 log units) above; measured number inside the range.
By their numbers in this assay, from the lowest: compound 3; then compounds 1 and 2 (each within the scatter of the next).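

In this assay, ethyl in place of hydrogen on the amide-type nitrogen gives a 2.6-fold lower number from compound 1 to compound 3 (0.42 log units; beyond the scatter), a modest step and the first in the series beyond the scatter. The amide hydrogen is therefore not required for inhibition at this level, and this nitrogen responds to change where the diethylamino-to-pyrrolidin-1-yl swap did not. Nothing available bears on the cause of this step.

As far as these compounds go, whether methyl or a longer chain such as propyl on this nitrogen would go further remains open. Also open, from the compounds shown here alone, is whether ethyl gives a similar step alongside the pyrrolidin-1-yl group of compound 2.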